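One Amine Swap, Measured Once and Expected Again

The compounds below may be only part of what the source reports. "The series", "measured", "known", "first", "only" and "open" are said of these compounds alone.

Compound 1 `CCNCC(=O)Nc1cc(OC)ccc1C(=O)c1ccc(OC)c2c1OC(C)(C)C=C2` and compound 3 `COc1ccc(C(=O)c2ccc(OC)c3c2OC(C)(C)C=C3)c(NC(=O)CN(C)C)c1` differ in a single place: dimethylamino in place of ethylamino on a saturated chain carbon bound to a carbonyl carbon. In a functional assay on HeLa cells (Homo sapiens) for antiproliferative activity, read by MTT assay, with a stated time of 48 h (a higher number here means a weaker inhibitor, a lower number a stronger inhibitor), compound 1 gives 2690 nM, and compound 3 gives 1050 nM, which amounts to a 2.6-fold lower number from compound 1 to compound 3 (0.41 log units; beyond the scatter). Compound 2 `CCNCC(=O)Nc1cc(OC)ccc1C(=O)c1ccc2c(c1)C=CC(C)(C)O2` carries the ethylamino group of compound 1 on a different core; the difference between the two cores is not broken down here. In this assay compound 2 gives 3110 nM, a value within the scatter of that of compound 1. Compound 4 `COc1ccc(C(=O)c2ccc3c(c2)C=CC(C)(C)O3)c(NC(=O)CN(C)C)c1` stands to compound 2 as compound 3 stands to compound 1, the change being dimethylamino in place of ethylamino on a saturated chain carbon bound to a carbonyl carbon in the same place. Because the same change gave a 2.6-fold lower number from compound 1 to compound 3 (0.41 log units; beyond the scatter), and because compound 2 gives 3110 nM close to compound 1, a step of similar size, a 2.4-fold lower number from compound 2 to compound 4 (0.38 log units; beyond the scatter), is expected. Compound 4 is therefore estimated at 1300 nM, between 600 nM and 3000 nM.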

Compound 4, half-maximal inhibitory concentration: 1260 nM
For compound 4 the middle estimate is 1.0-fold (0.01 log units) above the measured one; low and high end bracket the measured number.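

Set on the core of compound 2, dimethylamino in place of ethylamino gives a 2.5-fold lower number from compound 2 to compound 4 (0.39 log units; beyond the scatter) in this assay. Set beside the earlier step, the size of the change carries over from one core to the other: the same change on two cores in this assay, a 2.6-fold lower number (0.41 log units; beyond the scatter) from compound 1 to compound 3 and a 2.5-fold lower number (0.39 log units; beyond the scatter) from compound 2 to compound 4, 1.0-fold (0.02 log units) apart, within the scatter of two such steps. This rests on two cores and one cell assay, so it does not show that the step would hold on any other core, and it does not show why the number falls.

The compounds shown leave open how diethylamino or pyrrolidine would compare on a saturated chain carbon bound to a carbonyl carbon. They also leave open whether the step would persist with a longer chain carrying the amine.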